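The source may report more compounds than this note shows. Statements on the series, on what has been measured and on what is new or still open speak of the compounds shown alone.

Measured so far:
- compound 1 `O=C1/C(=C\c2ccc(F)cc2)c2ccccc2N1c1c(Cl)cccc1Cl`; in a functional assay on MCF7 cells (Homo sapiens) for cytotoxicity, read by MTT assay, with a stated time of 72 h (on this read-out higher numbers stand for an effect only at larger amounts of compound and lower numbers for an effect already at smaller amounts), compound 1 gives 9 ug/mL
- compound 2 `COc1ccc(/C=C2\C(=O)N(c3c(Cl)cccc3Cl)c3ccccc32)cc1`; in this assay compound 2 reaches only the limit > 100 ug/mL

Compound 2 thus sits at the upper end of the numbers shown, and its entry is a limit of the assay rather than a number (the limit of > 100 ug/mL in this assay, at which 1 of the 2 values shown sits). Among the compounds with values here, the one measured step in the pair, an at least 11-fold higher number from compound 1 to compound 2 (1.04 log units; beyond the scatter), is the only step so far and it is large.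

Compound 3 `O=C1/C(=C\c2cccc(Br)c2)c2ccccc2N1c1c(Cl)cccc1Cl` differs from compound 2 by 3-bromophenyl in place of 4-methoxyphenyl on a double-bonded chain carbon bound to a double-bonded ring carbon. The step from compound 1 to compound 2 bears directly on this, since it shows that exchanging a halogen on that aryl for methoxy moved the number beyond the scatter toward the limit. Compound 3 restores a halogen, here bromine, so the reverse direction is expected: the step of an at least 6.6-fold lower number from compound 2 to compound 3 (0.82 log units; beyond the scatter) is estimated to fall back toward the level of compound 1, though the aryl with 3-bromophenyl is not the same as that of compound 1 and the size is uncertain. Compound 3 is therefore expected to give about 15 ug/mL in this assay, with a range from 5 ug/mL to 60 ug/mL.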

Compound 3, concentration for half-maximal effect: 5 ug/mL
Beside the measured number, compound 3's estimate is 3.0-fold (0.48 log units) above it; the measured number falls inside the stated range.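

In this assay, the two halogen-bearing aryl groups on the double-bonded chain carbon bound to a double-bonded ring carbon cannot be told apart (a 1.8-fold lower number from compound 1 to compound 3 (0.26 log units; within the scatter)), although both the halogen and its place on the aryl differ. The large separation from 4-methoxyphenyl now appears in a second pair (an at least 20-fold lower number from compound 2 to compound 3 (1.30 log units; beyond the scatter)), so among the three compounds both halogen-bearing aryl groups stand on the low-number side, and compound 2 alone goes against that pattern. The entry for compound 2 is a limit and not a number, so both steps from it give only a minimum size: the limit of > 100 ug/mL in this assay, at which 1 of the 3 values shown sits.

The compounds shown leave open whether the separation belongs to methoxy itself or to its place on the aryl, since 3-methoxyphenyl and 4-bromophenyl do not appear among them. On these data alone, it is also open how an amine, a carboxylic acid or a longer alkoxy chain on that aryl would read out, and whether the same separation holds when the rest of the shared core changes.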